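Enaminone series: indolylamino to methoxyanilino exchange

The source may hold more compounds than are shown below. What is called first, only, known or untested is meant among the compounds shown, and "the series" means these compounds.

The series shares a core carrying an enaminone chain capped by an aryl amine. Compound 1 `COc1ccc(-c2nc(C(=O)/C=C\Nc3ccc4[nH]ccc4c3)c3ccccn23)cc1` gives, in a functional assay on MDA-MB-231 cells (Homo sapiens) for cytotoxicity, read by MTT assay, with a stated time of 48 h (on this read-out lower numbers stand for stronger inhibition and higher numbers for weaker inhibition), a value of 28700 nM. Of the two numbers available it is the higher one; the nearest number belongs to compound 3 `O=C(/C=C\Nc1cnc2ccccc2c1)c1nc(-c2ccccc2)n2ccccc12`, which gives 12300 nM in this assay, a gap said to lie beyond the usual scatter. Compound 2 `O=C(/C=C\Nc1ccc2cc[nH]c2c1)c1nc(-c2ccc(C(F)(F)F)cc2)n2ccccc12` reaches only a limit of this assay, > 30000 nM, and no number is known for it. That one of the three values sits at this limit is recorded as the limit of > 30000 nM in this assay, at which 1 of the 3 values shown sits.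

Compound 4 `COc1ccc(N/C=C\C(=O)c2nc(-c3ccc(OC)cc3)n3ccccc23)cc1` is the next entry. It differs from compound 1 in one place, 4-methoxyphenyl in place of 1H-indol-5-yl on an amine nitrogen. Going by the values given here, no measured step between two compounds of this set isolates a change at the amine, so no direction can be read from the data. The values of compound 1 and compound 3 both sit in a weak range, and the estimate treats the step from compound 1 to compound 4 as expected to stay within scatter, a 1.0-fold higher number from compound 1 to compound 4 (0.02 log units; within the scatter), with a fair chance of a limit. Compound 4 is expected to give about 30000 nM in this assay, between 12000 nM and 80000 nM.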

Compound 4, half-maximal inhibitory concentration: > 30000 nM
Compound 4 gave a limit, no number (the forecaster's own chance of this, stated with the estimate: 45%); the middle value lies on the limit itself.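

In this assay compound 4 gives a limit and not a number (> 30000 nM). Going by these compounds alone, this is the first reading of a change at the amine nitrogen, and the exchange of 1H-indol-5-yl for 4-methoxyphenyl is only a floor (an at least 1.0-fold higher number from compound 1 to compound 4 (0.01 log units; that floor lies within the scatter)), so it shows no gain, while a real loss cannot be told from no change. With the fused five-membered ring and its hydrogen-bond donor gone, the series still gains no measurable strength at this position, and the assay ceiling now accounts for more of the set: the limit of > 30000 nM in this assay, at which 2 of the 4 values shown sit.

Going by these compounds, how far the value would rise above the limit remains unknown, so the size of the exchange cannot be read, and compound 3 differs from the others in more than one place, which leaves its lower number unassigned to any single change. Also open, on these data alone, is whether a group of another kind on the amine nitrogen, such as a plain alkyl chain, a 4-hydroxyphenyl or an aryl ring carrying a carboxylic acid, would move the value in either direction on the shared core.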